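This account rests on a few compounds, and the source may have more. Where it says the series, first, only, none or still open, it means among the compounds named here.

Compound 1, `CC1=CC[C@@H]([C@@](C)(O)CCCC(C)(C)NC(=S)N/N=C\c2cccc(Cl)c2)CC1`: 26500 nM in a functional assay on OVCAR-3 cells (Homo sapiens) for cytotoxicity, read by sulforhodamine B assay; on this read-out lower numbers stand for stronger inhibition of growth and higher numbers for weaker inhibition of growth
Compound 2, `CC1=CC[C@@H]([C@@](C)(O)CCCC(C)(C)NC(=S)N/N=C\c2ccc(Cl)cc2)CC1`: 12800 nM in this assay

For the measured compounds named here, compound 2 gives the lowest of the two numbers; its nearest neighbour is compound 1, with a 2.1-fold lower number from compound 1 to compound 2 (0.32 log units; beyond the scatter) being the only measured step. Compound 3 is `CC1=CC[C@@H]([C@@](C)(O)CCCC(C)(C)NC(=S)N/N=C(/C)c2ccccc2)CC1`. It differs from compound 2 by a group of 9 heavy atoms (8 carbon, 1 nitrogen; one six-membered aromatic ring of carbon only) in place of a group of 9 heavy atoms (7 carbon, 1 nitrogen, 1 chlorine; one six-membered aromatic ring of carbon only), on an amide-type nitrogen. Going by the values given here, no measured step matches this change, so the expectation rests only on the single step between compound 1 and compound 2, which was modest. Compound 3 is therefore expected to give 20000 nM (range 8000 nM to 50000 nM) in this assay. This estimate corresponds to an expected step of a 1.6-fold higher number from compound 2 to compound 3 (0.19 log units; within the scatter).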

Compound 3, concentration for total growth inhibition: 59500 nM
Compound 3: the middle estimate sits 3.0-fold (0.47 log units) below what was measured; measured number above the stated range.
By their numbers in this assay, from the lowest: compound 2; then compound 1; then compound 3.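

In this assay, the group on the amide-type nitrogen matters beyond where the chlorine sits: compound 3, with a methyl on the carbon with a double bond to nitrogen and no chlorine on its ring, gives the highest number. The steps are a 4.6-fold higher number from compound 2 to compound 3 (0.67 log units; beyond the scatter) and a 2.2-fold higher number from compound 1 to compound 3 (0.35 log units; beyond the scatter). Nothing available here explains this shift.

Going by these compounds, compound 3 carries both differences at once, so the share of the missing chlorine and that of the added methyl stay open. On these data alone, the effect of a methoxy group on the ring also stays open.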